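A few compounds are considered here, and "the series" means these few. Any claim that something is new, unique, unknown or untested is made for them only; others in the source may bear on it.

Going by the values given here, compound 3 `C#CCSc1nc(Nc2ccc(Br)cc2)c2ccncc2n1` is the one compound of the three that returns a number in a functional assay on PC-3 cells (Homo sapiens) for inhibition, read by MTT assay, with a stated time of 72 h (on this read-out lower numbers stand for stronger inhibition and higher numbers for weaker inhibition), where compound 3 gives 26000 nM. Compound 1 `C#CCSc1nc(NCCC#N)c2ccncc2n1` reaches only the limit of > 80000 nM in this assay. Compound 2 `C#CCSc1nc(Nc2ccccc2Cl)c2ccncc2n1` likewise stops at the limit of > 80000 nM. The change to compound 4 `C#CCSc1nc(Nc2ccccc2O)c2ccncc2n1` is 2-hydroxyphenyl in place of 4-bromophenyl on a nitrogen on an aromatic ring. Among the compounds with values here, two measured steps bear on it, an at least 3.0-fold lower number from compound 2 to compound 3 (0.48 log units; beyond the scatter) and an at least 3.0-fold lower number from compound 1 to compound 3 (0.48 log units; beyond the scatter), both starting from the limit of > 80000 nM in this assay, at which 2 of the 3 values shown sit. The entering 2-hydroxyphenyl resembles the 2-chlorophenyl of compound 2 more than the departing 4-bromophenyl, and that group gave an at least 3.0-fold lower number from compound 2 to compound 3 (0.48 log units; beyond the scatter) when exchanged. The expected step is therefore a 2.3-fold higher number from compound 3 to compound 4 (0.36 log units; beyond the scatter), a rise, with a real chance that only a limit is reported. Compound 4 is estimated at 60000 nM, between 20000 nM and 150000 nM.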

Compound 4, half-maximal inhibitory concentration: 18700 nM
Compound 4: the middle estimate sits 3.2-fold (0.51 log units) above what was measured, outside the stated range (below it).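

In this assay, a 1.4-fold lower number from compound 3 to compound 4 (0.14 log units; within the scatter) leaves 2-hydroxyphenyl and 4-bromophenyl on this nitrogen indistinguishable. Hydroxy in place of chloro on an aromatic carbon gives an at least 4.2-fold lower number from compound 2 to compound 4 (0.63 log units; beyond the scatter), showing that the group on the phenyl ring, not the phenyl ring alone, decides whether a number is returned, and 2-hydroxyphenyl in place of 2-cyanoethyl gives an at least 4.2-fold lower number from compound 1 to compound 4 (0.63 log units; beyond the scatter). Both of these steps are lower bounds on size, since each starts from a limit: the limit of > 80000 nM in this assay, at which 2 of the 4 values shown sit.

As far as these compounds go, whether an amine or a carboxylic acid on the phenyl ring would match the hydroxy remains open. So does whether any group here could bring the number far beneath those of compound 3 and compound 4.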